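From Trifluoromethyl to Methylsulfanyl on the Shared Core

The source may report more compounds than this note shows. Statements on the series, on what has been measured and on what is new or still open speak of the compounds shown alone.

Among the compounds with values here, compound 2 `CC(C)(C)[C@H](C(=O)Nc1ncc(C(F)(F)F)s1)c1ccc(Cl)cc1` gives 1500 nM in a functional assay on CHO cells for agonist activity at Free fatty acid receptor 2 (Homo sapiens), read by cAMP accumulation (on this read-out lower numbers stand for stronger inhibition and higher numbers for weaker inhibition), the higher of the two numbers measured so far, while compound 1 `CC(C)(C)[C@H](C(=O)Nc1ncc(F)s1)c1ccc(Cl)cc1` gives 700 nM in this assay. Within the data shown here, the single measured step, a 2.1-fold higher number from compound 1 to compound 2 (0.33 log units; beyond the scatter), is the only guide to the present change. Compound 3 `CSc1cnc(NC(=O)[C@H](c2ccc(Cl)cc2)C(C)(C)C)s1` carries methylsulfanyl in place of trifluoromethyl on an aromatic carbon. Among the measured compounds shown here, no measured step involves methylsulfanyl, so only a small move beyond the scatter, if any, is expected, with a partial return toward compound 1 judged somewhat more likely than a further rise. Compound 3 is expected to give 1000 nM in this assay, within 400 nM to 2500 nM. The expected step is a 1.5-fold lower number from compound 2 to compound 3 (0.18 log units; within the scatter).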

Compound 3, half-maximal inhibitory concentration: 500 nM
Estimate against measurement, compound 3: 2.0-fold (0.30 log units) above, and the stated range covers the measured number.
By their numbers in this assay, from the lowest: compounds 3 and 1 (each within the scatter of the next); then compound 2.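

In this assay, a 3.0-fold lower number from compound 2 to compound 3 (0.48 log units; beyond the scatter) shows that this aromatic carbon tolerates a sulfur-linked group and that trifluoromethyl is the one that stands apart so far. The further step, a 1.4-fold lower number from compound 1 to compound 3 (0.15 log units; within the scatter), places methylsulfanyl level with fluoro, so two groups that share few of their counted features give values that cannot be told apart. Nothing measured here explains this. From the compounds shown here alone, whether a longer chain such as ethylsulfanyl, an amine or a carboxylic acid at this carbon would hold that level remains open.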